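The source may report more compounds than this note shows. Statements on the series, on what has been measured and on what is new or still open speak of the compounds shown alone.

Compound 1 `Cn1c(/C=C2\SC(=O)N(CC(=O)Nc3cc(C(C)(C)C)on3)C2=O)nc2ccccc21`: 31400 nM in a functional assay on DU-145 cells (Homo sapiens) for inhibition, read by MTT assay, with a stated time of 48 h; on this read-out higher numbers stand for weaker inhibition and lower numbers for stronger inhibition
Compound 2 `Cn1c(/C=C2\SC(=O)N(CC(=O)Nc3nc(-c4ccccc4)cs3)C2=O)nc2ccccc21`: 31400 nM

Compound 1 and compound 2 share the same core and differ only in the group on the amide-type nitrogen, where compound 2 carries 4-phenyl-1,3-thiazol-2-yl in place of 5-(tert-butyl)-1,2-oxazol-3-yl. That single step, no change at the digits printed from compound 1 to compound 2 (within the scatter), leaves the read-out where it was, so compound 1 stands level with compound 2 and its value is the only anchor for what follows.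

Compound 3 `CC1CN(C(=O)CN2C(=O)S/C(=C\c3nc4ccccc4n3C)C2=O)CC(C)O1` is built from the same core, but the change is of another kind: 2,6-dimethylmorpholin-4-yl in place of (5-(tert-butyl)-1,2-oxazol-3-yl)amino on a carbonyl carbon. The amide hydrogen of compound 1 is gone, and the aromatic ring on the amide-type nitrogen is replaced by a saturated ring bonded directly to the carbonyl carbon. Among the measured compounds shown here, the one measured step bears on it only loosely, since it exchanged one aromatic ring for another on the same nitrogen and was flat; no measured pair tests the loss of the hydrogen-bond donor. On that basis compound 3 is expected to show a step of about no change at the digits printed from compound 1 to compound 3 (within the scatter) in this assay, that is, none beyond the scatter. Compound 3 is therefore estimated at 31400 nM, in a range from 10000 nM to 100000 nM.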

Compound 3, half-maximal inhibitory concentration: > 50000 nM
Compound 3: no number, only a limit; the forecaster's own chance of this, stated with the estimate: 20%; middle value at least 1.5-fold (0.20 log units) from the limit.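

Among the compounds shown here, until now the only step had exchanged one aromatic ring for another on the amide-type nitrogen, whereas here a saturated ring without the amide hydrogen is bonded directly to the carbonyl carbon, and in this assay the outcome is an at least 1.5-fold higher number from compound 1 to compound 3 (0.20 log units; that floor lies within the scatter). The reading for compound 3 is a limit of the assay and not a number: the limit of > 50000 nM in this assay, at which 1 of the 3 values shown sits. This change at the position therefore gives no lower number, unlike a result that would have shown the amide hydrogen and the aromatic ring to be dispensable for inhibition of these cells, yet the floor of the step lies within the scatter and the step has no upper end, so its true size cannot be read.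

The compounds shown leave open whether the outcome follows from the loss of the amide hydrogen or from the saturated ring itself, since both changed in the one step. A methyl group on the amide nitrogen of compound 1 would address the first, and a morpholin-4-yl without the two methyl groups or a piperidin-1-yl on the same carbonyl carbon would address the second.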